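Chloromethyl in place of the carbonyl-side group, two cores

This account rests on a few compounds, and the source may have more. Where it says the series, first, only, none or still open, it means among the compounds named here.

Notes on the series; all readings come from a functional assay on NALM-6 cells (Homo sapiens); a higher number here means a weaker inhibitor, a lower number a stronger inhibitor.

Compound 1 `CC(=O)N[C@@H](CSC/C=C(\C)CCC=C(C)C)C(=O)C=[N+]=[N-]`: > 100000 nM, a limit of the assay.
Compound 2 `CCCCCCCCCCCCSC[C@H](NC(C)=O)C(=O)C=[N+]=[N-]`: 15400 nM.
Compound 3 `CC(=O)N[C@@H](CSC/C=C(\C)CCC=C(C)C)C(=O)CCl`: > 100000 nM, also a limit of the assay.

For the measured compounds named here, compound 2 gives the only number in this assay among the three measured. Compound 3 differs from compound 1 by a group of 2 heavy atoms (1 carbon, 1 chlorine; no ring) in place of a group of 3 heavy atoms (1 carbon, 2 nitrogen; no ring), on a carbonyl carbon; the step that the two limits leave unreadable from compound 1 to compound 3 cannot be sized because of the limit of > 100000 nM in this assay, at which 2 of the 3 values shown sit. The difference between the core of compound 1 and the core of compound 2 is not broken down here. Compound 4 `CCCCCCCCCCCCSC[C@H](NC(C)=O)C(=O)CCl`, not yet measured, differs from compound 2 by a group of 2 heavy atoms (1 carbon, 1 chlorine; no ring) in place of a group of 3 heavy atoms (1 carbon, 2 nitrogen; no ring), on a carbonyl carbon, the same change as from compound 1 to compound 3. No readable size exists to carry over. For compound 4 the estimate is 20000 nM, from 3000 nM to 100000 nM, an expected step of a 1.3-fold higher number from compound 2 to compound 4 (0.11 log units; within the scatter). This rests only on compound 2 at 15400 nM and is correspondingly uncertain.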

Compound 4, half-maximal inhibitory concentration: 2000 nM
Compound 4: the middle estimate sits 10-fold (1.00 log units) above what was measured; the measured number lies below the stated range.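

Chloromethyl in place of the group of one carbon and two nitrogens, on a carbonyl carbon, brings in this assay a 7.7-fold lower number from compound 2 to compound 4 (0.89 log units; beyond the scatter). The same change from compound 1 to compound 3 cannot be read, because neither compound has a number, only a limit of the assay: the limit of > 100000 nM in this assay, at which 2 of the 4 values shown sit. The change therefore has a readable size on one core only, and these results do not show whether that size, or even its direction, carries over to the core of compound 1.

On these data alone, how an amine or a carboxylic acid in place of chloromethyl would read on either core remains open. So does the effect of a longer chain on the core of compound 4.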